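Formyl in Place of Chloro on an Aromatic Carbon

The source may hold more compounds than are shown below. What is called first, only, known or untested is meant among the compounds shown, and "the series" means these compounds.

In a functional assay on MCF7 cells (Homo sapiens) for cytotoxicity, read by MTT assay, with a stated time of 48 h (a lower number here means a stronger inhibitor, a higher number a weaker inhibitor), compound 1 (`O=c1c(-c2cc(O)cc(O)c2)cnc2ccccn12`) gives 2000 nM and compound 2 (`O=c1cc(-c2ccc(Cl)cc2)nc2ccccn12`) gives 1800 nM. These two numbers lie within the scatter of each other, so compound 2 stands level with compound 1 and neither can be ranked over the other. Compound 3 (`O=Cc1ccc(-c2cc(=O)n3ccccc3n2)cc1`) keeps the core of compound 2 but carries formyl in place of chloro on an aromatic carbon, para to a large group: formyl in place of chloro on an aromatic carbon. The two measured compounds differ in more than one place, so the data hold no direct guide to what this exchange does. No shift beyond the scatter is expected, in either direction, and the estimated change is a 1.2-fold higher number from compound 2 to compound 3 (0.09 log units; within the scatter). For compound 3 the expected value is 2200 nM, with an estimated range from 800 nM to 6000 nM.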

Compound 3, half-maximal inhibitory concentration: 2500 nM
Compound 3: the middle estimate sits 1.1-fold (0.06 log units) below what was measured; low and high end bracket the measured number.
By their numbers in this assay, from the lowest: compounds 2, 1 and 3 (each within the scatter of the next).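

In this assay, formyl in place of chloro on this aromatic carbon, para to a large group, gives a 1.4-fold higher number from compound 2 to compound 3 (0.14 log units; within the scatter). Within the data shown here, this is the first comparison that changes one place only, and it shows that this exchange moves the number no further than the scatter. Chloro can thus give way at this position to a group that brings a hydrogen-bond acceptor and a double bond outside aromatic rings with no measurable shift in this assay, though no measured property is at hand to account for this result.

Going by these compounds, whether the position would stay as level with an amine, a carboxylic acid or a longer chain remains open. Also open, on these data alone, is whether the same exchange would read alike on the core of compound 1.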